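Pyrrole nitrogen substituent in the piperidine amide series

A few compounds are considered here, and "the series" means these few. Any claim that something is new, unique, unknown or untested is made for them only; others in the source may bear on it.

Measured compounds:
- Compound 1 `O=C(NC1CCN(Cc2ccc(Cl)c(Cl)c2)CC1)c1csc([N+](=O)[O-])c1` gives 92 nM in an assay on HEK293 cells for displacement of a labelled ligand from melanin-concentrating hormone receptor 1 (Homo sapiens); a lower number here means a stronger inhibitor, a higher number a weaker inhibitor.
- Compound 2 `O=C(COc1cccc(Cl)c1)NC1CCN(Cc2ccc(-c3ccccn3)cc2)CC1` gives 120 nM in this assay.
- Compound 3 `COc1ccc(-n2ccc(CN3CCC(NC(=O)COc4cccc(Cl)c4)CC3)c2)cc1` gives 100 nM in this assay.

The three numbers sit close together. Compound 3 stands second highest of the three, but its gap to compound 1 and its gap to compound 2 are both within the scatter, so no order among the three can be drawn from these data.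

Compound 4 `O=C(COc1cccc(Cl)c1)NC1CCN(Cc2ccn(-c3ccon3)c2)CC1` is the next compound for this assay. Compared with compound 3 the change is 1,2-oxazol-3-yl in place of 4-methoxyphenyl on an aromatic nitrogen of a five-membered aromatic ring with 1 nitrogen, two ring bonds from the ring atom that bears a large group. The amide, the piperidine and the chlorophenoxyacetyl part are unchanged.

Among the measured compounds shown here, no step between two measured compounds covers a change at this position, so the size of the effect has no precedent. The expected step from compound 3 to compound 4 in this assay is a 2.0-fold higher number from compound 3 to compound 4 (0.30 log units; within the scatter), leaning towards a somewhat higher number but with a wide spread that includes no change beyond the scatter. Compound 4 is estimated at 200 nM, with a range from 60 nM to 700 nM.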

Compound 4, half-maximal inhibitory concentration: 1500 nM
Beside the measured number, compound 4's estimate is 7.5-fold (0.88 log units) below it; the whole stated range lies below it.
By their numbers in this assay, from the lowest: compounds 1, 3 and 2 (each within the scatter of the next); then compound 4.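

In this assay, the group on the aromatic nitrogen of the five-membered aromatic ring with 1 nitrogen has a clear influence on the number: 1,2-oxazol-3-yl in place of 4-methoxyphenyl gives a 15-fold higher number from compound 3 to compound 4 (1.18 log units; beyond the scatter), a large step beyond the scatter. The earlier compounds shown here could not show this, as their numbers lay within the scatter of one another and no two of them differed in one place. This single step replaces a six-membered aromatic ring of carbon only, bearing a methoxy group, with a five-membered aromatic ring with 2 hetero atoms, so it shows the effect of the whole exchange and does not separate the contribution of the ring from that of the methoxy group.

Nothing at hand explains the size of this step. Still open, as far as these compounds go, is how the number would respond on the same nitrogen to an unsubstituted phenyl, which would separate the methoxy group from the ring, or to a 4-hydroxyphenyl, a pyridin-3-yl or a 5-methyl-1,2-oxazol-3-yl.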